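The compounds below may be only part of what the source reports. "The series", "measured", "known", "first", "only" and "open" are said of these compounds alone.

Compound 1 `CN(C)CCCNc1nc(-c2ccc(NC(=O)Nc3ccccc3Cl)cc2)nc2ccsc12` is the starting point of this series. In a functional assay on NCI-H460 cells (Homo sapiens) for cytotoxicity, read by MTT assay, with a stated time of 72 h (on this read-out higher numbers stand for weaker inhibition and lower numbers for stronger inhibition), compound 1 gives 430 nM. Compound 2 `CN(C)CCCNc1nc(-c2ccc(NC(=O)Nc3ccc(Cl)cc3Cl)cc2)nc2ccsc12` differs from it by a single change, (chloro in place of hydrogen on an aromatic carbon), and in this assay compound 2 gives 1020 nM. That change produced a 2.4-fold higher number from compound 1 to compound 2 (0.38 log units; beyond the scatter).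

Compound 3 `CN(C)CCCNc1nc(-c2ccc(NC(=O)Nc3ccccc3Cl)cc2)nc2c(Cl)c(Cl)sc12` carries a different core; how the core of compound 3 differs from the core of compound 1 is not broken down here. In this assay compound 3 gives 490 nM, which sits within the scatter of compound 1.

Compound 4 `CN(C)CCCNc1nc(-c2ccc(NC(=O)Nc3ccc(Cl)cc3Cl)cc2)nc2c(Cl)c(Cl)sc12` has not been measured in this assay. It stands to compound 3 as compound 2 stands to compound 1: the change is chloro in place of hydrogen on an aromatic carbon, the same change seen twice among these compounds, at a place described in identical terms.

Because the earlier instance gave a 2.4-fold higher number from compound 1 to compound 2 (0.38 log units; beyond the scatter), the step on the core of compound 3 is expected to be of similar size, a 2.3-fold higher number from compound 3 to compound 4 (0.37 log units; beyond the scatter). Compound 4 is therefore estimated to give 1150 nM in this assay, with a range from 550 nM to 2400 nM.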

Compound 4, half-maximal inhibitory concentration: 980 nM
Compound 4: the middle estimate sits 1.2-fold (0.07 log units) above what was measured; the measured number falls inside the stated range.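

In this assay, the chloro that turns 2-chlorophenyl into 2,4-dichlorophenyl on the core of compound 3 gave a 2.0-fold higher number from compound 3 to compound 4 (0.30 log units; within the scatter). The change therefore carried from one core to the other without a detectable difference in its size: the same change on two cores in this assay, a 2.4-fold higher number (0.38 log units; beyond the scatter) from compound 1 to compound 2 and a 2.0-fold higher number (0.30 log units; within the scatter) from compound 3 to compound 4, 1.2-fold (0.07 log units) apart, within the scatter of two such steps. Going by these compounds alone, this agreement rests on only one pair on each core, and the second step on its own does not rise beyond the scatter, so it does not establish a firm loss on that core or show that the change would behave alike on any further core.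

The compounds shown leave open whether a fluoro, methyl or methoxy group entering at the same place, para to a large group, would follow the chloro. They also leave open whether the step would keep its size if the dimethylamino group at the end of the side chain gave way to a morpholine or a piperazine.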